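A few compounds are considered here, and "the series" means these few. Any claim that something is new, unique, unknown or untested is made for them only; others in the source may bear on it.

Growth inhibition in a functional assay on 786-0 cells (Homo sapiens) for inhibition, read by sulforhodamine B assay, with a stated time of 48 h (a higher number here means a weaker inhibitor of growth, a lower number a stronger inhibitor of growth), measured values:
- compound 1 `Nc1cc(N)c2nc(-c3ccccc3)c(Oc3ccc(Cl)c(Cl)c3)nc2c1`: 12600 nM
- compound 2 `Nc1cc(N)c2nc(-c3ccccc3)c(NCc3ccc(Cl)c(Cl)c3)nc2c1`: 13200 nM
- compound 3 `CCOC(=O)[C@H](CCC(=O)O)NC(=O)c1ccc(Sc2nc3cc(N)cc(N)c3nc2-c2ccccc2)cc1`: 24500 nM

All three numbers lie close together. Compound 2 sits between compound 1 and compound 3, and both gaps are within the scatter, so no order among the three can be read from this assay.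

Compound 4 `COc1ccc(CNc2nc3cc(N)cc(N)c3nc2-c2ccccc2)cc1` follows from compound 2 by 4-methoxyphenyl in place of 3,4-dichlorophenyl on a saturated chain carbon bound to a nitrogen on an aromatic ring. For the measured compounds named here, no measured pair in the set shows a like change, so the size of the step is unknown; the expectation is for no step beyond the scatter in this assay, with a slight lean toward a higher number. Compound 4 is estimated at 18000 nM, range 6000 nM to 50000 nM, which means an expected step of a 1.4-fold higher number from compound 2 to compound 4 (0.13 log units; within the scatter).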

Compound 4, concentration for 50% growth inhibition: 15100 nM
For compound 4 the middle estimate is 1.2-fold (0.08 log units) above the measured one; the range from low to high includes it.
By their numbers in this assay, from the lowest: compounds 1, 2, 4 and 3 (each within the scatter of the next).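

In this assay the series now has its first single-place pair, with a 1.1-fold higher number from compound 2 to compound 4 (0.06 log units; within the scatter) for 4-methoxyphenyl in place of 3,4-dichlorophenyl on a saturated chain carbon bound to a nitrogen on an aromatic ring. Losing both chlorines and gaining one hydrogen-bond acceptor at this position therefore leaves the read-out within the scatter. No available evidence bears on this result.

On these data alone, whether a basic amine or a carboxylic acid on the ring at this position would give a step beyond the scatter stays open. So does the effect of a longer chain between the ring and the nitrogen.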